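Replacing cyano with carbamoyl on the anilide series

The compounds below may be only part of what the source reports. "The series", "measured", "known", "first", "only" and "open" are said of these compounds alone.

Measured in a functional assay on CLL cells (Homo sapiens) for cytotoxicity, read by MTT assay, with a stated time of 48 h; on this read-out higher numbers stand for an effect only at larger amounts of compound and lower numbers for an effect already at smaller amounts:
Compound 1 `C=C(CC)C(=O)c1ccc(OCC(=O)Nc2cccc(C(=O)O)c2)c(Cl)c1Cl` gives 20600 nM
Compound 2 `C=C(CC)C(=O)c1ccc(OCC(=O)Nc2ccc(C#N)cc2)c(Cl)c1Cl` gives 7800 nM

Compound 2 holds the lower of the two numbers. Compound 3 `C=C(CC)C(=O)c1ccc(OCC(=O)Nc2ccc(C(N)=O)cc2)c(Cl)c1Cl` differs from it by carbamoyl in place of cyano on an aromatic carbon, para to a large group (carbamoyl in place of cyano on an aromatic carbon). For the measured compounds named here, only one measured step bears on this, and only loosely, as it concerns a different change (a 2.6-fold lower number from compound 1 to compound 2 (0.42 log units; beyond the scatter)). That modest step leads to the expectation of a smaller move towards a higher number in this assay, possibly within the scatter. The expected change is small (a 1.4-fold higher number from compound 2 to compound 3 (0.15 log units; within the scatter)). Compound 3 is estimated at 11000 nM (expected range 5000 nM to 24000 nM).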

Compound 3, half-maximal effective concentration: 3700 nM
Compound 3: the middle estimate sits 3.0-fold (0.47 log units) above what was measured; measured number outside the range, below it.
By their numbers in this assay, from the lowest: compound 3; then compound 2; then compound 1.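

In this assay, carbamoyl in place of cyano on an aromatic carbon, para to a large group, gives a 2.1-fold lower number from compound 2 to compound 3 (0.32 log units; beyond the scatter), so the number at this position can fall further with a group that carries a hydrogen-bond donor. The same aryl change set against the 3-carboxyphenyl group gives a 5.6-fold lower number from compound 1 to compound 3 (0.75 log units; beyond the scatter), making compound 3 the lowest of the three. No measurement shown accounts for this move. Compound 1 differs from compound 3 in both group and place, so the two are not separated. As far as these compounds go, whether an amine or a carboxylic acid on that same aromatic carbon would lower the number further remains open.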